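Three Measured Compounds and One Unmeasured Relative

The source may hold more compounds than are shown below. What is called first, only, known or untested is meant among the compounds shown, and "the series" means these compounds.

compound 1 `C#CCO/N=C1/C[C@@H](c2ccc(OC)cc2)Oc2cc(OC)c(CC=C(C)C)cc21`: 64%
compound 2 `COc1cc2c(cc1CC=C(C)C)C(=O)C[C@@H](c1ccc(Oc3cccc([N+](=O)[O-])c3)cc1)O2`: 37%
compound 3 `COc1ccc([C@@H]2C/C(=N/OCc3cn(-c4cccc(CO)c4)nn3)c3cc(CC=C(C)C)c(OC)cc3O2)cc1`: 43%

All three were tested in a functional assay on A549 cells (Homo sapiens) for inhibition, read by sulforhodamine B assay, with a stated time of 48 h, tested at 50 uM; a higher number here means more inhibition of growth at the concentration tested, a lower number less inhibition of growth. Compound 1 gives 64%, compound 2 gives 37%, and compound 3 gives 43%. On these numbers compound 3 stands second highest of the three: its value lies within the scatter of that of compound 2, while compound 1 sits beyond the scatter above it.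

Compound 4 `COc1ccc([C@@H]2C/C(=N/OCc3cn(-c4cc(OC)c(OC)c(OC)c4)nn3)c3cc(CC=C(C)C)c(OC)cc3O2)cc1` has not been measured in this assay. It differs from compound 3 in a single place: 3,4,5-trimethoxyphenyl in place of 3-(hydroxymethyl)phenyl on an aromatic nitrogen. Going by the values given here, no pair among the measured compounds shows this kind of exchange, so nothing here tells how large such a step tends to be. With that absence of any comparable step, a change of modest size in either direction is expected, and the step expected is a number 2 percentage points higher from compound 3 to compound 4 (within the scatter), which would not reach beyond the scatter. Compound 4 is therefore estimated at 45%, with a range from 25% to 65%.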

Compound 4, percent growth inhibition at one concentration: 28%
For compound 4 the middle estimate is 17 percentage points above the measured one, within the range that was stated.
By their numbers in this assay, from the lowest: compounds 4, 2 and 3 (each within the scatter of the next, the first and the last beyond it); then compound 1.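

Placing 3,4,5-trimethoxyphenyl in place of 3-(hydroxymethyl)phenyl on an aromatic nitrogen gives a number 15 percentage points lower from compound 3 to compound 4 (beyond the scatter) in this assay and is the only step here that can be read, which shows that growth inhibition at this concentration responds to the group carried at this position. The exchange changes several counted features at once: the entering group has more heavy atoms and more hydrogen-bond acceptors, and it has no hydrogen-bond donor, so this single pair cannot separate their contributions. No measurement available here bears on why the number falls.

Going by these compounds, it remains open whether the step comes from losing the hydroxymethyl group or from gaining the three methoxy groups, a question that an unsubstituted phenyl group could help to address. The compounds shown also leave open how an aminomethyl group or a carboxylic acid would behave on this aromatic ring.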